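Working notes: from compound 2 to compound 3

The source may hold more compounds than are shown below. What is called first, only, known or untested is meant among the compounds shown, and "the series" means these compounds.

- compound 1 `COc1ccc(NC(=O)NCCNS(=O)(=O)c2ccc(-c3ccccc3OCc3ccccc3)s2)cc1`: > 50000 nM
- compound 2 `O=S(=O)(NCCNC(=S)Nc1cccc(Cl)c1)c1ccc(-c2ccccc2OCc2ccccc2)s1`: 10200 nM

Going by the values given here, in an ADME assay on HEK-293T cells (Homo sapiens) for cytotoxicity, read by CCK-8 assay, with a stated time of 48 h (a lower number here means a stronger inhibitor, a higher number a weaker inhibitor), compound 2 gives 10200 nM, the only actual number so far. Compound 1 reads > 50000 nM, which is a limit and not a number. The series therefore rests on little: the limit of > 50000 nM in this assay, at which 1 of the 2 values shown sits.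

Compound 3 `O=[N+]([O-])c1ccc(NC(=S)NCCNS(=O)(=O)c2ccc(-c3ccccc3OCc3ccccc3)s2)cc1` has not yet been measured. It carries 4-nitrophenyl in place of 3-chlorophenyl on an amide-type nitrogen.

Among the compounds with values here, one measured step bears on this change, and only loosely: an at least 4.9-fold lower number from compound 1 to compound 2 (0.69 log units; beyond the scatter). Its size is a bound, as one end of it is a limit. Within the data shown here, it also replaces more than the group on that nitrogen, and no measured step exchanges that group alone. As far as these compounds go, compound 2 at 10200 nM is thus the nearest anchor, and direction stays open. An expected step of a 1.2-fold higher number from compound 2 to compound 3 (0.07 log units; within the scatter) would stay small, with no shift beyond the scatter expected in this assay. For compound 3 the estimated value is 12000 nM, with an expected range of 4000 nM to 40000 nM.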

Compound 3, half-maximal inhibitory concentration: 8900 nM
Estimate against measurement, compound 3: 1.3-fold (0.13 log units) above; the measured number falls inside the stated range.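

In this assay, the exchange of 4-nitrophenyl for 3-chlorophenyl on the amide-type nitrogen whose other neighbour is the thiocarbonyl carbon gives a 1.1-fold lower number from compound 2 to compound 3 (0.06 log units; within the scatter), the only step shown that exchanges this group alone, and the two compounds cannot be told apart at this position. The wider step, an at least 5.6-fold lower number from compound 1 to compound 3 (0.74 log units; beyond the scatter), lies beyond the scatter, as does an at least 4.9-fold lower number from compound 1 to compound 2 (0.69 log units; beyond the scatter), so both thiocarbonyl compounds, with different aryl groups on that nitrogen, read lower than compound 1. The size of each of these two steps remains only a bound, because compound 1 stands at a limit of the assay: the limit of > 50000 nM in this assay, at which 1 of the 3 values shown sits.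

The compounds shown do not separate the carbonyl-to-thiocarbonyl exchange from the exchange of the aryl group, since the steps from compound 1 replace the whole group on the amine nitrogen at once. As far as these compounds go, how a cyclohexyl or an aminophenyl group on the amide-type nitrogen, or a longer chain in place of the present linker, would read in this assay also stays open.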